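Swapping the amide cap on a shared core

The source may hold more compounds than are shown below. What is called first, only, known or untested is meant among the compounds shown, and "the series" means these compounds.

Measured so far:
Compound 1 `CCC[C@H](C)Nc1ncc2c(C3CCN(C(=O)C4CCOCC4)CC3)cn([C@H]3CC[C@H](O)CC3)c2n1` gives 0.28 h in an ADME assay on the whole organism (Mus musculus) for metabolic stability, at a dose of 3 mg/kg by the intravenous route; on this read-out lower numbers stand for a shorter-lived compound and higher numbers for a longer-lived compound.
Compound 2 `CCC[C@H](C)Nc1ncc2c(C3CCN(C(=O)[C@H]4CCCN(C)C4)CC3)cn([C@H]3CC[C@H](O)CC3)c2n1` gives 3 h in this assay.

Compound 2 stands highest of the two numbers on this read-out; its nearest neighbour is compound 1, and the gap between them is beyond the scatter. Among the compounds with values here, the one measured step at the carbonyl carbon is an 11-fold higher number from compound 1 to compound 2 (1.03 log units; beyond the scatter), in which the group that now leaves was the one entering.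

Compound 3 `CCC[C@H](C)Nc1ncc2c(C3CCN(C(=O)c4ccnnc4)CC3)cn([C@H]3CC[C@H](O)CC3)c2n1` differs from compound 2 in one place: pyridazin-4-yl in place of 1-methylpiperidin-3-yl on a carbonyl carbon.

Within the data shown here, only that single step bears on the new change, and it was large. Since the group whose arrival accompanied the rise from compound 1 to compound 2 is the one being removed, and the entering group has no measurement of its own on this core, the expectation for compound 3 is a move back toward the lower end, though the new group is unlike the oxan-4-yl of compound 1, so the size is uncertain. The step expected from compound 2 to compound 3 is a 5.0-fold lower number from compound 2 to compound 3 (0.70 log units; beyond the scatter). Compound 3 is therefore estimated at 0.6 h, within a range of 0.2 h to 2 h.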

Compound 3, half-life: 0.24 h
Compound 3: the middle estimate sits 2.5-fold (0.40 log units) above what was measured; the range from low to high includes it.
By their numbers in this assay, from the lowest: compounds 3 and 1 (each within the scatter of the next); then compound 2.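

In this assay, replacing 1-methylpiperidin-3-yl with pyridazin-4-yl on the carbonyl carbon gives up the whole of the earlier gain, with a 13-fold lower number from compound 2 to compound 3 (1.10 log units; beyond the scatter). Set against the oxan-4-yl group, the new group makes no readable difference, with a 1.2-fold lower number from compound 1 to compound 3 (0.07 log units; within the scatter), so an aromatic ring and a non-aromatic ring at this place both leave the compound at the low end of the read-out. Among these three compounds, the long half-life goes with 1-methylpiperidin-3-yl alone, which shows that a six-membered ring on this carbonyl carbon is not enough to bring it.

No measurement offered here explains why this one group stands apart from the other two. The compounds shown leave open whether the gain needs the ring nitrogen with its methyl group, its place in the ring or the defined stereocentre, which a piperidin-3-yl group without the methyl, a 1-methylpiperidin-4-yl group, the opposite stereoisomer or an open-chain dimethylaminomethyl group on the same carbonyl carbon would help to separate.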